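The compounds below may be only part of what the source reports. "The series", "measured", "known", "first", "only" and "open" are said of these compounds alone.

Compound 1 `CCCCCCCCCCCCc1ccc(-c2c(C)[nH]c(=O)n2C)cc1` is measured in a functional assay on brain (Rattus norvegicus, strain Wistar) for inhibition (a lower number here means a stronger inhibitor, a higher number a weaker inhibitor), and gives 13000 nM. Compound 2 `CCCCCCCCCCCCCCCCCCc1ccc(-c2c(C)[nH]c(=O)n2C)cc1` carries hexyl in place of hydrogen on a saturated chain carbon, ten or more bonds along the chain from an aromatic carbon. In this assay compound 2 reaches only a limit, > 100000 nM. The step of an at least 7.6-fold higher number from compound 1 to compound 2 (0.88 log units; beyond the scatter) can therefore be read only as far as the limit of > 100000 nM in this assay, at which 1 of the 3 values shown sits, allows. Compound 3 `CCCCCCCCCCCCOc1ccc(-c2c(C)[nH]c(=O)n2C2CCCCC2)cc1` has a different core; the difference between the two cores is not broken down here. In this assay compound 3 gives 52400 nM, a weaker result than compound 1.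

Compound 4 `CCCCCCCCCCCCCCCCCCOc1ccc(-c2c(C)[nH]c(=O)n2C2CCCCC2)cc1` is not yet measured. Relative to compound 3 it carries hexyl in place of hydrogen on a saturated chain carbon, ten or more bonds along the chain from an oxygen on an aromatic ring. Within the data shown here, this is the same kind of change as the one from compound 1 to compound 2, though the surroundings of the place differ: in compound 4 the chain is counted from an oxygen on an aromatic ring, in compound 2 from an aromatic carbon. Resting on the step of an at least 7.6-fold higher number from compound 1 to compound 2 (0.88 log units; beyond the scatter), a step of about a 5.7-fold higher number from compound 3 to compound 4 (0.76 log units; beyond the scatter) is expected. Compound 4 is thus estimated at 300000 nM, most likely reported as a limit rather than a number, within a range from 80000 nM to 1500000 nM.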

Compound 4, half-maximal inhibitory concentration: > 100000 nM
Compound 4: no number, only a limit; the forecaster's own chance of this, stated with the estimate: 80%; the middle value lies beyond the limit too.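

In this assay compound 4 gives only a limit, > 100000 nM, and not an exact number. The same hexyl change on the core of compound 3 can therefore be stated only as a floor, an at least 1.9-fold higher number from compound 3 to compound 4 (0.28 log units; that floor lies within the scatter), and that floor alone does not establish a weaker result, so the carry-over from one core to the other is consistent with the data but not proven: the same change on two cores in this assay, an at least 7.6-fold higher number (0.88 log units; beyond the scatter) from compound 1 to compound 2 and an at least 1.9-fold higher number (0.28 log units; that floor lies within the scatter) from compound 3 to compound 4; the limit leaves it open whether they differ. The true size of neither step can be read, and no claim that the change acts equally on both cores can be made, because both longer-chain compounds stop at the same limit: the limit of > 100000 nM in this assay, at which 2 of the 4 values shown sit.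

The compounds shown leave open how the numbers move at chain lengths between the two on each core, for example with a tetradecyl chain. They also leave open whether a chain ending in a carboxylic acid or an amine would give a measurable number instead of a limit.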